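The source may hold more compounds than are shown below. What is called first, only, known or untested is meant among the compounds shown, and "the series" means these compounds.

In an ADME assay on microsomes from liver (Rattus norvegicus) for metabolic stability, read by LC-MS, using NADPH, with a stated time of 10 min, tested at 0.5 uM (a lower number here means that less of the compound is left, a higher number that more of the compound is left), compound 3 (`Cc1cc(-c2cc(Cl)c(OC[C@@](C)(N)CC(C)C)cn2)ccn1`) gives 73%, the lowest of the three numbers available. Compound 1 (`COC(=O)Nc1cc(-c2cc(Cl)c(OC[C@@](C)(N)CC(C)C)cn2)ccn1`) gives 99%, and compound 2 (`COC(=O)Nc1cc(-c2cc(C)c(OC[C@@](C)(N)CC(C)C)cn2)ccn1`) gives 100%. The next compound, compound 4 (`Cc1cc(-c2cc(C)c(OC[C@@](C)(N)CC(C)C)cn2)ccn1`), differs from compound 3 by one exchange: methyl in place of chloro on an aromatic carbon. This is methyl in place of chloro on an aromatic carbon, opposite the ring nitrogen.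

The same exchange has been measured once, in a number 1 percentage points higher from compound 1 to compound 2 (within the scatter), and that step lies within the scatter. It is the closest guide, but it has a limit: compound 1 and compound 2 both stand at the very top of the scale, where little room is left for a rise. A real difference could therefore stay hidden there. The other measured step, a number 26 percentage points lower from compound 1 to compound 3 (beyond the scatter), is modest but beyond the scatter. It replaces (methoxycarbonyl)amino with methyl, the group that compound 3 and compound 4 share, and so it shows that the setting of the exchange differs from the one already tested.

No step beyond the scatter is expected in this assay, though the uncertainty is wide. The expected step is a number 2 percentage points lower from compound 3 to compound 4 (within the scatter). For compound 4 the estimated value is 71%, with an expected range from 55% to 86%.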

Compound 4, percent of the compound remaining: 72%
Compound 4: the middle estimate sits 1 percentage points below what was measured; measured number inside the range.
By their numbers in this assay, from the lowest: compounds 4 and 3 (each within the scatter of the next); then compounds 1 and 2 (each within the scatter of the next).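

Read well below the top of the scale in this assay, methyl in place of chloro, opposite the ring nitrogen, gives a number 1 percentage points lower from compound 3 to compound 4 (within the scatter), so the flat result from the earlier pair now has a counterpart where a rise or a fall would have had room to appear. Across the four compounds shown, the exchange therefore makes no readable difference on either core: the same change on two cores in this assay, a number 1 percentage points higher (within the scatter) from compound 1 to compound 2 and a number 1 percentage points lower (within the scatter) from compound 3 to compound 4, 2 percentage points apart, within the scatter of two such steps The step from (methoxycarbonyl)amino to methyl also holds when methyl rather than chloro stands opposite the ring nitrogen, at a number 28 percentage points lower from compound 2 to compound 4 (beyond the scatter), so in these four compounds the two exchanges do not appear to interfere with each other: the same change on two cores in this assay, a number 26 percentage points lower (beyond the scatter) from compound 1 to compound 3 and a number 28 percentage points lower (beyond the scatter) from compound 2 to compound 4, 2 percentage points apart, within the scatter of two such steps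

Chloro and methyl are the only groups shown at this place, so it remains open whether a methoxy group, a nitrile or an ethyl group would read the same. On these data alone, it also remains open which part of the (methoxycarbonyl)amino group goes with the higher numbers, a question that a free amine or an acetylamino group in its place could help to settle.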